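A Methyl-to-Hydrogen Swap on Three Diarylureas

The source may hold more compounds than are shown below. What is called first, only, known or untested is meant among the compounds shown, and "the series" means these compounds.

In a functional assay on RPMI-8226 cells (Homo sapiens) for inhibition, read by sulforhodamine B assay, with a stated time of 48 h (on this read-out lower numbers stand for higher toxicity in this test and higher numbers for lower toxicity in this test), compound 1, `COc1cc(-c2nn(-c3cccc(NC(=O)Nc4cc(C(F)(F)F)cc(C(F)(F)F)c4)c3)cc2-c2ccncc2)ccc1Cl`, reaches only a limit of the test rather than a number, > 50000 nM. Compound 2, `COc1cc(-c2nn(-c3cccc(NC(=O)Nc4ccc(Cl)c(Cl)c4)c3)cc2-c2ccncc2)ccc1Cl`, likewise gives only a limit in this assay, > 50000 nM. Compound 3, `O=C(Nc1cccc(-n2cc(-c3ccncc3)c(-c3ccc(Cl)c(O)c3)n2)c1)Nc1ccc(Cl)c(Cl)c1`, also gives a limit in this assay, > 32500 nM. Compound 2 and compound 3 differ by hydrogen in place of methyl on an oxygen on an aromatic ring, and the step that the two limits leave unreadable from compound 2 to compound 3 cannot be read because the limit of > 50000 nM in this assay, at which 2 of the 3 values shown sit, and the limit of > 32500 nM in this assay, at which 1 of the 3 values shown sits, sit at its two ends. How the core of compound 1 differs from the core of compound 2 is not broken down here.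

Compound 4, `O=C(Nc1cccc(-n2cc(-c3ccncc3)c(-c3ccc(Cl)c(O)c3)n2)c1)Nc1cc(C(F)(F)F)cc(C(F)(F)F)c1`, is not yet measured. It differs from compound 1 by hydrogen in place of methyl on an oxygen on an aromatic ring, the same change as that from compound 2 to compound 3, at the same place. Among the measured compounds shown here, because compound 1 sits at the limit of > 50000 nM in this assay, at which 2 of the 3 values shown sit, and because the one measured step of this kind, a step that the two limits leave unreadable from compound 2 to compound 3, shows no readable movement, compound 4 is expected to remain near the top of the test. The step from compound 1 is estimated as a step that the limit leaves unreadable from compound 1 to compound 4. Compound 4 is estimated at 60000 nM, most likely between 20000 nM and 200000 nM, and another limit is the likeliest outcome.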

Compound 4, concentration lethal to 50% of the cells: > 50000 nM
Compound 4 ended at the assay's limit; the forecaster's own chance of this, stated with the estimate: 85%; the middle value is on the limit's open side.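

In this assay compound 4 gives > 50000 nM, a limit of the test and not a number. Among the compounds shown here, compound 1 also gives only a limit, and no step from methoxy to hydroxy can be read between compound 1 and compound 4. The compounds shown leave open whether this change moves the read-out at all, and what number compound 1, compound 2, compound 3 or compound 4 would give in place of a limit.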